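Swapping the aminopyrimidine for a pyrazole: expected cytotoxicity

The source may report more compounds than this note shows. Statements on the series, on what has been measured and on what is new or still open speak of the compounds shown alone.

Compound 1, `Nc1nccc(-c2c(-c3ccc(F)cc3)nn3c(NC4CCCC4)cccc23)n1`: in an ADME assay on Vero cells (Chlorocebus sabaeus) for cytotoxicity (on this read-out higher numbers stand for lower toxicity in this test and lower numbers for higher toxicity in this test), compound 1 gives 46000 nM.
Compound 2, `Fc1ccc(-c2nn3c(NC4CCCC4)cccc3c2-c2ccnc(NC3CCCC3)n2)cc1`: in this assay compound 2 is reported only as a limit, > 160000 nM.

Compound 1 holds the only plain number shown; the other value is a limit. Going by the values given here, the one measured step, an at least 3.4-fold higher number from compound 1 to compound 2 (0.54 log units; beyond the scatter), reaches (the limit of > 160000 nM in this assay, at which 1 of the 2 values shown sits). Compound 3, `Fc1ccc(-c2nn3c(NC4CCCC4)cccc3c2-c2cn[nH]c2)cc1`, differs from compound 1 by 1H-pyrazol-4-yl in place of 2-aminopyrimidin-4-yl on an aromatic carbon. Among the compounds with values here, no measured step covers this change, since the step from compound 1 to compound 2 alters a different group. No step beyond the scatter is therefore expected. Compound 3 is estimated at 60000 nM, within 20000 nM to 160000 nM, which would be a 1.3-fold higher number from compound 1 to compound 3 (0.12 log units; within the scatter).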

Compound 3, half-maximal cytotoxic concentration: 10000 nM
The estimate for compound 3 lay 6.0-fold (0.78 log units) above the measured number; the whole stated range lies above it.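

In this assay, putting 1H-pyrazol-4-yl on this aromatic carbon gives a 4.6-fold lower number from compound 1 to compound 3 (0.66 log units; beyond the scatter), which means higher toxicity in this test. The earlier step changed only what sits on the amine nitrogen, whereas this one shows that replacing the whole ring at this place also moves the read-out beyond the scatter. Nothing given here accounts for the change. The swap alters ring size and the hydrogen-bond acceptor count together, and the compounds shown cannot separate the two. Going by these compounds, how a phenyl ring on this carbon, or a methyl group on the pyrazole nitrogen, would read remains open.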